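Nitro-sulfonyl benzamides: varying the amine cap of the shared core

The source may hold more compounds than are shown below. What is called first, only, known or untested is meant among the compounds shown, and "the series" means these compounds.

Measured so far
Compound 1, `CS(=O)(=O)c1ccc(C(=O)NCC(=O)N2CCCCC2)cc1[N+](=O)[O-]`: 44000 nM
Compound 2, `CS(=O)(=O)c1ccc(C(=O)NCC(=O)N2CCN(c3ccccc3F)CC2)cc1[N+](=O)[O-]`: > 60000 nM

In an assay on isolated protein for inhibition of thyroid hormone receptor alpha (Homo sapiens), read by fluorescence polarization (on this read-out higher numbers stand for weaker inhibition and lower numbers for stronger inhibition), compound 1 gives 44000 nM. Compound 2 returns only a limit of this assay, > 60000 nM, so no number is known for it; this value is the limit of > 60000 nM in this assay, at which 1 of the 2 values shown sits. Compound 3, `CN1CCN(C(=O)CNC(=O)c2ccc(S(C)(=O)=O)c([N+](=O)[O-])c2)CC1`, keeps the shared core of compound 2 and differs in one place: methyl in place of 2-fluorophenyl on an amine nitrogen in a ring. Going by the values given here, no measured step covers this change. Among the compounds with values here, both values known so far are weak, and compound 3 is expected to remain weak, with an expected step of a number no higher from compound 2 to compound 3 (the limit leaves the size open) that need not exceed the scatter. Compound 3 is estimated at 60000 nM, in the range 20000 nM to 200000 nM.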

Compound 3, half-maximal inhibitory concentration: > 60000 nM
Compound 3 ended at the assay's limit; the forecaster's own chance of this, stated with the estimate: 60%; the middle value lies on the limit itself.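

With methyl in place of 2-fluorophenyl on an amine nitrogen in a ring, the series still gives no readable value, and the step between compound 2 and compound 3 cannot be read because both are limits: the limit of > 60000 nM in this assay, at which 2 of the 3 values shown sit.

In this assay, the change from piperidin-1-yl to 4-methylpiperazin-1-yl on a carbonyl carbon gives an at least 1.3-fold higher number from compound 1 to compound 3 (0.13 log units; that floor lies within the scatter), so no real loss can be claimed.

Going by these compounds, how compound 2 and compound 3 rank remains open. So does whether a benzyl group or a longer chain ending in a carboxylic acid on that nitrogen would give a readable value.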